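Aryl variation on a shared core: chloro to hydrogen

This account rests on a few compounds, and the source may have more. Where it says the series, first, only, none or still open, it means among the compounds named here.

Compound 2 `OC(CCn1nc2c(Br)c(Br)c(Br)c(Br)c2n1)c1cccc(Cl)c1` gives 0% in a functional assay on MCF7 cells (Homo sapiens) for antiproliferative activity, read by MTT assay, with a stated time of 24 h, tested at 100 uM (on this read-out higher numbers stand for a weaker effect at the one concentration tested and lower numbers for a stronger effect), level with compound 1 `OC(CCn1nc2c(Br)c(Br)c(Br)c(Br)c2n1)c1ccc(F)cc1`, which gives 0%; the step of no change at the digits printed from compound 1 to compound 2 (within the scatter). Compound 3 `OC(CCn1nc2c(Br)c(Br)c(Br)c(Br)c2n1)c1ccccc1` differs from compound 2 by hydrogen in place of chloro on an aromatic carbon. Among the measured compounds shown here, only the step from compound 1 to compound 2 bears on a change of the aryl substituent, and it was flat, with both measured compounds sitting at the floor of the read-out. No movement beyond the scatter is expected in this assay . Compound 3 is estimated at 0%, ranging from 0% to 12%. The expected step is therefore no change at the digits printed from compound 2 to compound 3 (within the scatter).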

Compound 3, a percentage reported as activity, at one concentration (the size of the read-out at that concentration, not a potency): 13%
The estimate for compound 3 lay 13 percentage points below the measured number; measured number outside the range, above it.
By their numbers in this assay, from the lowest: compounds 1 and 2 (each within the scatter of the next); then compound 3.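

In this assay, the aryl substituent is not indifferent: a number 13 percentage points higher from compound 2 to compound 3 (beyond the scatter), and a number 13 percentage points higher from compound 1 to compound 3 (beyond the scatter), both toward a weaker effect at the one concentration tested. The flat step between 3-chlorophenyl and 4-fluorophenyl therefore compared two halogen-bearing rings that sit level, while the unsubstituted phenyl of compound 3 stands apart from both. No evidence at hand bears on the reason for this shift. From the compounds shown here alone, it remains open whether a non-halogen substituent on the ring, such as methoxy or an amine, would give numbers level with compound 1 and compound 2 or with compound 3.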